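This account rests on a few compounds, and the source may have more. Where it says the series, first, only, none or still open, it means among the compounds named here.

Compound 1 (`COc1ccc(CNC(=O)/C=C/c2coc3cc(O)ccc3c2=O)cc1`) stands at > 100000 nM in a functional assay on A549 cells (Homo sapiens) for inhibition, read by MTT assay, with a stated time of 48 h (a lower number here means a stronger inhibitor, a higher number a weaker inhibitor), and that value is a limit of the assay, not a number. Compound 2 (`COc1ccc(CNC(=O)/C=C/c2coc3cc(OC)ccc3c2=O)cc1`) gives 22500 nM with methyl in place of hydrogen on an oxygen on an aromatic ring. Compound 3 (`O=C(/C=C/c1coc2cc(O)ccc2c1=O)NCc1ccc(F)cc1F`) keeps the core of compound 1 and changes elsewhere: 2,4-difluorophenyl in place of 4-methoxyphenyl on a saturated chain carbon bound to an amide-type nitrogen. For the measured compounds named here, the one measured step, an at least 4.4-fold lower number from compound 1 to compound 2 (0.64 log units; beyond the scatter), lies at another place, so it gives no direct size for this change. Only a small move toward a lower number is expected in this assay, namely an at least 1.4-fold lower number from compound 1 to compound 3 (0.15 log units; that floor lies within the scatter). Compound 3 is estimated at 70000 nM, within an expected range of 20000 nM to 150000 nM.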

Compound 3, half-maximal inhibitory concentration: 6610 nM
The estimate for compound 3 lay 11-fold (1.02 log units) above the measured number; measured number outside the range, below it.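

In this assay, 2,4-difluorophenyl in place of 4-methoxyphenyl on a saturated chain carbon bound to an amide-type nitrogen gives an at least 15-fold lower number from compound 1 to compound 3 (1.17 log units; beyond the scatter), so this position, and not only the oxygen changed in compound 2, moves the number. Compound 1 gives > 100000 nM, which is a limit of the assay and not a number, so the step is only a floor: the limit of > 100000 nM in this assay, at which 1 of the 3 values shown sits.

The change removes the methoxy and brings in both fluorines at once, and the compounds shown do not separate these. Still open, going by these compounds, is how an amine or a carboxylic acid in place of the 2,4-difluorophenyl would read.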